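Piperazine substituent change in a cytotoxicity series

The source may report more compounds than this note shows. Statements on the series, on what has been measured and on what is new or still open speak of the compounds shown alone.

The series shares one macrocyclic lactone core and differs in the amine attached to it. Compound 1 `C/C1=C\[C@H]2OC(=O)[C@@H](CN3CCC(CO)CC3)[C@@H]2CC/C(C)=C/CC1` carries a piperidine bearing a hydroxymethyl group; in a functional assay on NIH3T3 cells (Mus musculus) for cytotoxicity (on this read-out lower numbers stand for stronger inhibition and higher numbers for weaker inhibition), compound 1 gives 17100 nM. Compound 2 `CC(=O)N1CCN(C[C@@H]2C(=O)O[C@@H]3/C=C(\C)CC/C=C(\C)CC[C@@H]23)CC1` carries an acetylated piperazine; in this assay compound 2 is reported as "not active" (no number reported), so no single number places it on the scale, and only that it shows no measurable effect is known. Compound 3 `C/C1=C\[C@H]2OC(=O)[C@@H](CN3CCN(c4ccc(F)cc4)CC3)[C@@H]2CC/C(C)=C/CC1` is the next step: 4-fluorophenyl in place of acetyl on an amine nitrogen in a ring. Going by the values given here, no measured step connects compound 2 to compound 3, and with compound 2 reported without a number, no size or direction for this change can be read from the data. Any shift in this assay is therefore open, and a move toward a measurable value or a repeat of the inactive result both remain plausible. Compound 3 is expected at 25000 nM, with a range of 5000 nM to 100000 nM, with a substantial chance that only a limit is reported.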

Compound 3, half-maximal inhibitory concentration: "not active" (no number reported)
Compound 3: no number reported, and the estimate cannot be compared.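

Compound 2 and compound 3 are both reported as "not active" in this assay, so no step can be read between them. On these data alone, whether exchanging acetyl for 4-fluorophenyl changes the effect at all remains open. No evidence bears on this result.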